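From 4-chlorophenyl to 4-methylphenyl: protein binding notes

This account rests on a few compounds, and the source may have more. Where it says the series, first, only, none or still open, it means among the compounds named here.

Values so far in an ADME assay on a cell-free system (plasma, Rattus norvegicus) for protein binding, are as follows
compound 1 `Cc1ccc(-c2cc(C(=O)N[C@H](C)c3ccc(C(F)(F)F)[n+]([O-])c3)cc(C(C)(C)O)c2)nc1` gives 62.4% as its value
compound 2 `Cc1ccc(-c2cc(C(=O)N[C@H](C)c3ccc(C(F)(F)F)nc3)cc(-c3ncccc3F)c2)nc1` gives 98.6% as its value
compound 3 `C[C@@H](NC(=O)c1cc(-c2ccc(Cl)cc2)cc(C(C)(C)O)c1)c1ccc(C(F)(F)F)[n+]([O-])c1` gives 97.4% as its value

Compound 3 at 97.4% and compound 2 at 98.6% lie within the scatter of each other, so no order is read between them. Compound 1 at 62.4% stands well apart from both, with far more free compound.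

Compound 4 `Cc1ccc(-c2cc(C(=O)N[C@H](C)c3ccc(C(F)(F)F)[n+]([O-])c3)cc(C(C)(C)O)c2)cc1` follows from compound 3 by a single change (methyl in place of chloro on an aromatic carbon) in which methyl takes the place of chloro on an aromatic carbon, para to a large group, so that 4-chlorophenyl becomes 4-methylphenyl.

Going by the values given here, only one measured step bears on this, and only loosely: a 14-fold lower unbound fraction from compound 1 to compound 3 (1.16 log units; beyond the scatter) was large, but it exchanged one whole ring group for another at this place. The present change keeps the six-membered aromatic ring of carbon only and alters just the substituent on it. Among the compounds with values here, no measured step isolates chloro against methyl, so the size rests on judgement. A small shift towards slightly more free compound is expected, inside the scatter. a 1.5-fold higher unbound fraction from compound 3 to compound 4 (0.19 log units; within the scatter) is the expected step in this assay and nothing larger is foreseen. For compound 4 the expected value is 96% within an estimated range of 92.5% to 98% on this read-out.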

Compound 4, plasma protein binding: 95.4%
Estimate against measurement, compound 4: 1.2-fold (0.06 log units) (unbound fraction) below; measured number inside the range.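

In this assay, going by these compounds alone, methyl in place of chloro, on an aromatic carbon para to a large group, gives a 1.8-fold higher unbound fraction from compound 3 to compound 4 (0.25 log units; within the scatter); this is the first reading that isolates the substituent at this position while the six-membered aromatic ring of carbon only stays in place. The ring exchange at the same place now has two readings, a 14-fold lower unbound fraction from compound 1 to compound 3 (1.16 log units; beyond the scatter) and an 8.2-fold lower unbound fraction from compound 1 to compound 4 (0.91 log units; beyond the scatter), so the separation of compound 1 from the compounds carrying the carbon-only ring, beyond the scatter in both steps, does not rest on chloro alone. Nothing available explains either the small step or the two larger ones.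

Going by these compounds, it remains open whether this position stays as tolerant in this assay with a different kind of group in place of the methyl of 4-methylphenyl, such as an amine, a carboxylic acid or a longer chain. On these data alone, it is equally open whether chloro and methyl would read alike on the core of compound 2, where the other groups differ.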